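Moving the Chlorine on the Phenyl Group

A few compounds are considered here, and "the series" means these few. Any claim that something is new, unique, unknown or untested is made for them only; others in the source may bear on it.

Of the compounds shown here, three with a shared core have been measured in a functional assay on microsomes for inhibition, with a stated time of 1 h; a lower number here means a stronger inhibitor, a higher number a weaker inhibitor. Compound 1 `CCOC(=O)c1cnn(-c2nc(-c3ccccc3F)c(C#N)c(=O)n2C)c1N` gives 94 ug/mL, compound 2 `CCOC(=O)c1cnn(-c2nc(-c3cccc(OC)c3OC)c(C#N)c(=O)n2C)c1N` gives 57 ug/mL, and compound 3 `CCOC(=O)c1cnn(-c2nc(-c3ccccc3Cl)c(C#N)c(=O)n2C)c1N` gives 102 ug/mL. These numbers lie within the usual scatter of one another, so compound 3 cannot be told apart from the other two. Compound 4 `CCOC(=O)c1cnn(-c2nc(-c3ccc(Cl)cc3)c(C#N)c(=O)n2C)c1N` has the same atoms as compound 3, joined differently: 4-chlorophenyl in place of 2-chlorophenyl on an aromatic carbon. In short, 4-chlorophenyl stands in place of 2-chlorophenyl.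

Two measured steps involve compound 3 and a change of the group on this same aromatic carbon. Chloro in place of fluoro gave a 1.1-fold higher number from compound 1 to compound 3 (0.04 log units; within the scatter), and 2-chlorophenyl in place of 2,3-dimethoxyphenyl gave a 1.8-fold higher number from compound 2 to compound 3 (0.25 log units; within the scatter). The remaining step, a 1.6-fold lower number from compound 1 to compound 2 (0.22 log units; within the scatter), changes that same group. Among the compounds with values here, none of these steps moves a chlorine to another ring position, so the data offer no direct precedent. All three steps stayed within the scatter, so no step beyond the scatter is expected in this assay, and no direction can be favoured. The expected change is a 1.1-fold lower number from compound 3 to compound 4 (0.05 log units; within the scatter). In this assay the estimated value for compound 4 is 90 ug/mL, with an expected range from 45 ug/mL to 180 ug/mL.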

Compound 4, half-maximal inhibitory concentration: 88 ug/mL
Beside the measured number, compound 4's estimate is 1.0-fold (0.01 log units) above it; the range from low to high includes it.
By their numbers in this assay, from the lowest: compounds 2, 4, 1 and 3 (each within the scatter of the next).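

Within the data shown here, compound 4 brings the only change here that moves a chlorine around the phenyl group instead of swapping one group for another: 4-chlorophenyl in place of 2-chlorophenyl gives a 1.2-fold lower number from compound 3 to compound 4 (0.06 log units; within the scatter) in this assay, so the place of the chlorine makes no readable difference in this set. The other two new steps, a 1.5-fold higher number from compound 2 to compound 4 (0.19 log units; within the scatter) and a 1.1-fold lower number from compound 1 to compound 4 (0.03 log units; within the scatter), also stay within the scatter, which means that all four compounds now form one flat group, with none going against it, and none can be ranked above another. No measurement shown here bears on why this group is so flat.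

As far as these compounds go, what stays open is whether any change on this aromatic carbon can produce a step beyond the scatter in this assay, for instance an amine or a carboxylic acid on the phenyl group, or a longer chain in place of the whole ring. All four compounds also keep the same ethyl ester, nitrile and methyl group on the shared core, so these compounds cannot say how much those parts matter.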